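Substituting the ring nitrogen of compound 1: an expected shift

A few compounds are considered here, and "the series" means these few. Any claim that something is new, unique, unknown or untested is made for them only; others in the source may bear on it.

Compound 1 `O=C1c2c[n+]([O-])c3ccccc3c2C(=O)c2[nH]c3ccccc3c21` carries a hydrogen on its aromatic nitrogen. In a toxicity assay on L02 cells (Homo sapiens) for cytotoxicity, read by MTT assay, with a stated time of 72 h (a lower number here means a stronger inhibitor, a higher number a weaker inhibitor), compound 1 gives 400 nM, the second highest of the three numbers measured. Compound 2 `CC1(C)OCC(Cn2cc(Cn3c4c(c5ccccc53)C(=O)c3c[n+]([O-])c5ccccc5c3C4=O)nn2)O1` gives 120 nM in this assay, and compound 3 `O=C1c2c[n+]([O-])c3ccccc3c2C(=O)c2c1c1ccccc1n2Cc1cn([C@H]2O[C@H](CO)[C@@H](O)[C@H]2O)nn1` gives 950 nM. Among the compounds with values here, the only single-point step among the measured compounds, a 7.9-fold higher number from compound 2 to compound 3 (0.90 log units; beyond the scatter), concerns a swap within a side chain already attached to that nitrogen, not the attachment itself. Compound 4 `CN1CCN(CCCn2c3c(c4ccccc42)C(=O)c2c[n+]([O-])c4ccccc4c2C3=O)CC1` differs from compound 1 by 3-(4-methylpiperazin-1-yl)propyl in place of hydrogen on an aromatic nitrogen. Within the data shown here, no measured step matches this change, so the guidance is indirect: compounds 2 and 3 show that side chains on this nitrogen can land either side of compound 1, one below and one above. The expected step is therefore small, a 1.3-fold lower number from compound 1 to compound 4 (0.12 log units; within the scatter), and could fall in either direction. For compound 4 the estimate in this assay is 300 nM, with a plausible range from 80 nM to 1200 nM.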

Compound 4, half-maximal inhibitory concentration: 230 nM
Compound 4: middle estimate off by 1.3-fold (0.12 log units), on the high side, and the stated range covers the measured number.
By their numbers in this assay, from the lowest: compounds 2, 4 and 1 (each within the scatter of the next, the first and the last beyond it); then compound 3.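

Replacing the hydrogen on the aromatic nitrogen with 3-(4-methylpiperazin-1-yl)propyl gives, in this assay, a 1.7-fold lower number from compound 1 to compound 4 (0.24 log units; within the scatter). Within the data shown here, this is the first direct reading of what a side chain does at this position, since the earlier step between compound 2 and compound 3 only exchanged one side chain for another. Even so large a replacement for a single hydrogen leaves the number within the usual scatter, and no measurement at hand accounts for this result.

The compounds shown leave open whether a shorter or longer chain between the aromatic nitrogen and the piperazine ring would give the same reading. They also leave open what a morpholine ring, a simple primary amine or a carboxylic acid at the end of the propyl chain would do.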